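The source may hold more compounds than are shown below. What is called first, only, known or untested is meant among the compounds shown, and "the series" means these compounds.

Measured so far:
compound 1 `CCN(CC)C(=S)SCC1=CCOC1=O`, 136000 nM
compound 2 `O=C1CC2(CO1)CSC(=S)N2c1ccccc1`, 128000 nM
compound 3 `CN1CCN(C(=S)SCC2=CCOC2=O)CC1`, 14300 nM

In a functional assay on EC9706 cells (Homo sapiens) for antiproliferative activity, read by MTT assay, with a stated time of 72 h (a higher number here means a weaker inhibitor, a lower number a stronger inhibitor), compound 1 gives 136000 nM, the highest of the three numbers. Compound 2, at 128000 nM, sits within the scatter of that figure, so no order between compound 1 and compound 2 can be read. Compound 3, at 14300 nM, lies beyond the scatter and carries the lowest number of the three. Compound 4 `CCNC(=S)SCC1=CCOC1=O` is not yet measured; relative to compound 1 it carries hydrogen in place of ethyl on an amide-type nitrogen. For the measured compounds named here, no step of this kind has been measured. Compound 1 and compound 3 differ in more than one place, so no size can be borrowed from that gap. The expected step is a 1.1-fold higher number from compound 1 to compound 4 (0.04 log units; within the scatter), none beyond the scatter. Compound 4 is estimated at 150000 nM, between 50000 nM and 450000 nM.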

Compound 4, half-maximal inhibitory concentration: 44400 nM
Beside the measured number, compound 4's estimate is 3.4-fold (0.53 log units) above it; measured number outside the range, below it.
By their numbers in this assay, from the lowest: compound 3; then compound 4; then compounds 2 and 1 (each within the scatter of the next).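

In this assay, for the compounds shown here, the change from diethylamino to ethylamino gives a 3.1-fold lower number from compound 1 to compound 4 (0.49 log units; beyond the scatter) and is the first single-place step. It shows that the substitution on this amide-type nitrogen registers in the read-out: hydrogen in place of one ethyl moves the number beyond the scatter, though the step is modest in size. No measured evidence accounts for this step.

On these data alone, whether a longer chain such as propyl in place of the remaining ethyl, or a free amino group carrying hydrogen in its place, moves the number further in either direction stays open.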